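Replacing 4-Ethoxyphenyl with 3-Fluorophenyl: One Step Still Unmeasured

The source may report more compounds than this note shows. Statements on the series, on what has been measured and on what is new or still open speak of the compounds shown alone.

Of the compounds shown here, three have so far been tested in an ADME assay on HEK293 cells (Homo sapiens) for cytotoxicity, with a stated time of 72 h (on this read-out lower numbers stand for an effect already at smaller amounts and higher numbers for an effect only at larger amounts of compound), and none has yielded a number. Compound 1 `C=C[C@@](C)(/C=C/c1ccc(O)c(/C=C/C#N)c1)CCC=C(C)C` gives > 36600 nM as a limit of the assay. Compound 2 `C=C[C@@](C)(/C=C/c1ccc(O)c(/C=C/c2ccc(Cl)c(Cl)c2)c1)CCC=C(C)C` gives > 36600 nM as a limit too. Compound 3 `CCOc1ccc(/C=C/[C@@](C)(/C=C/c2ccc(O)cc2)CCC=C(C)C)cc1` stands at > 36600 nM and this is again only a limit. The whole set thus rests on the limit of > 36600 nM in this assay, at which 3 of the 3 values shown sit, with no exception among the three compounds.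

The structural change to compound 4 `CC(C)=CCC[C@](C)(/C=C/c1ccc(O)cc1)/C=C/c1cccc(F)c1` is 3-fluorophenyl in place of 4-ethoxyphenyl on a double-bonded chain carbon bound to a double-bonded chain carbon so that 3-fluorophenyl takes the place of 4-ethoxyphenyl on a double-bonded chain carbon bound to a double-bonded chain carbon. Among the measured compounds shown here, the only measured step of this kind is a step that the two limits leave unreadable from compound 1 to compound 2 with other groups exchanged, and it offers no size to carry over. The expectation therefore rests on compound 3 at > 36600 nM and on the other two limits, and no direction can be argued from them. A step beyond the usual scatter is not expected, and the estimated change is a step that the limit leaves unreadable from compound 3 to compound 4 with a report as a limit the likeliest outcome. The estimated value for compound 4 is 40000 nM within an expected range of 18000 nM to 80000 nM for this measurement.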

Compound 4, half-maximal effective concentration: > 36600 nM
Compound 4 gave a limit, no number; the forecaster's own chance of this, stated with the estimate: 80%; the middle value does not contradict the limit.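

In this assay compound 4 gives > 36600 nM, which is a limit and not a number. Among the compounds shown here, compound 3 also stands only at a limit, so no step between compound 3 and compound 4 can be read. The compounds shown leave open whether any of them reaches a half-maximal effect and how 3-fluorophenyl compares with 4-ethoxyphenyl: the limit of > 36600 nM in this assay, at which 4 of the 4 values shown sit.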